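The compounds below may be only part of what the source reports. "The series", "measured", "known", "first", "only" and "open" are said of these compounds alone.

In a functional assay on MCF7 cells (Homo sapiens) for inhibition, read by MTT assay, with a stated time of 72 h (a lower number here means a stronger inhibitor, a higher number a weaker inhibitor), compound 1 `COc1cc(NC(C)CCCNC(=O)NNC(=O)Nc2ccc(Cl)cc2)c2ncccc2c1` gives 180 nM and compound 2 `COc1cc(NC(C)CCCNC(=O)NNC(=O)Nc2ccc(C(F)(F)F)cc2)c2ncccc2c1` gives 100 nM. Compound 3 `COc1cc(NC(C)CCCNC(=O)Nc2ccc(F)cc2)c2ncccc2c1`, at 26000 nM, has the highest number of the three, beyond the scatter from both. Compound 4 `COc1cc(NC(C)CCCNC(=O)Nc2cccc(C(F)(F)F)c2)c2ncccc2c1` carries one change from compound 3: 3-(trifluoromethyl)phenyl in place of 4-fluorophenyl on an amide-type nitrogen. Going by the values given here, two measured steps bear on it. Trifluoromethyl in place of chloro gave only a 1.8-fold lower number from compound 1 to compound 2 (0.26 log units; within the scatter), whereas the large 140-fold higher number from compound 1 to compound 3 (2.16 log units; beyond the scatter) came with the loss of the ((4-chlorophenyl)carbamoyl)amino group, which compound 4 also lacks. No change beyond the scatter is therefore expected in this assay, with an estimated 1.3-fold lower number from compound 3 to compound 4 (0.11 log units; within the scatter). For compound 4 the expected value is 20000 nM, with an estimated range of 7000 nM to 60000 nM.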

Compound 4, half-maximal inhibitory concentration: 3300 nM
For compound 4 the middle estimate is 6.1-fold (0.78 log units) above the measured one, and the stated range ends above it.
By their numbers in this assay, from the lowest: compounds 2 and 1 (each within the scatter of the next); then compound 4; then compound 3.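

In this assay, the aryl group on the amide-type nitrogen matters even without the ((4-chlorophenyl)carbamoyl)amino group: 3-(trifluoromethyl)phenyl in place of 4-fluorophenyl gives a modest gain (a 7.9-fold lower number from compound 3 to compound 4 (0.90 log units; beyond the scatter)). This recovers only part of what that group's absence costs, as 3-(trifluoromethyl)phenyl in its place still leaves a large gap (an 18-fold higher number from compound 1 to compound 4 (1.26 log units; beyond the scatter)). The compounds shown leave open whether the gain follows the trifluoromethyl itself or the loss of fluorine, and how a phenyl carrying an amine or a carboxylic acid would read here. No measurement at hand explains the gain.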